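The source may report more compounds than this note shows. Statements on the series, on what has been measured and on what is new or still open speak of the compounds shown alone.

Measured so far in a functional assay with Alpha-1A adrenergic receptor (Homo sapiens) as the target, read by calcium flux; a lower number here means a smaller maximal response, a higher number a larger maximal response:
- compound 1, `Cn1nccc1-c1ccccc1NCC1=NCCN1`: 108%
- compound 2, `CC(C)n1nccc1-c1ccccc1NCC1=NCCN1`: 0%
- compound 3, `Cc1nc(-c2ccccc2NCC2=NCCN2)n(C)n1`: 98%

Compound 2 stands lowest of the three numbers. Its nearest neighbour is compound 3, whose maximal response lies well beyond the scatter above it, and compound 1 lies further above still. Compound 1 and compound 3 give maximal responses that fall within the scatter of each other, so no order is read between them.

Compound 4, `CCn1nccc1-c1ccccc1NCC1=NCCN1`, is not yet measured in this assay. It differs from compound 2 in one place: hydrogen in place of methyl on a saturated chain carbon bound to an aromatic nitrogen and a saturated chain carbon.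

Going by the values given here, one measured step bears on this change. The step of a number 108 percentage points lower from compound 1 to compound 2 (beyond the scatter) shows that replacing methyl by isopropyl on the aromatic nitrogen removed the maximal response entirely. The change from compound 2 to compound 4 partly undoes that step, reading isopropyl to ethyl. Whether the maximal response comes back in proportion or stays lost cannot be read from the data; both compound 1 and compound 2 mark the ends, and nothing lies between them. Compound 4 is therefore expected to give a maximal response part-way back toward that of compound 1, with wide uncertainty: the step of a number 55 percentage points higher from compound 2 to compound 4 (beyond the scatter) is the expected one. The estimate for compound 4 in this assay is 55%, with a range from 5% to 100%.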

Compound 4, largest response reached (reported as maximal response), in percent of the reference or control that the assay uses: 81%
Compound 4: the middle estimate sits 26 percentage points below what was measured; low and high end bracket the measured number.
By their numbers in this assay, from the lowest: compound 2; then compound 4; then compounds 3 and 1 (each within the scatter of the next).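

Along the series on the aromatic nitrogen, the maximal response in this assay proves to be graded rather than all-or-none: going from isopropyl to ethyl gives a number 81 percentage points higher from compound 2 to compound 4 (beyond the scatter) and so restores most of what isopropyl lost, which shows that a substituent larger than methyl is tolerated on this nitrogen and that the full loss appears only with isopropyl. Ethyl still does not match methyl, however, since the step from methyl to ethyl is a number 27 percentage points lower from compound 1 to compound 4 (beyond the scatter) and is modest beside the large one that follows, so the response falls unevenly, with most of the fall in the last carbon added. Nothing here gives a reason for this uneven fall.

The three substituents leave chain length and branching tied together, so a straight propyl chain or a cyclopropyl group on the same nitrogen would be needed to tell whether the added carbon or the branch at the carbon bound to the nitrogen goes with the lost response. Also open, on these data alone, are a plain hydrogen on this nitrogen and whether ethyl and isopropyl behave the same way on the core of compound 3.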